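A Hydroxylated Alkyl Group Replaces Trifluoromethoxy

The source may hold more compounds than are shown below. What is called first, only, known or untested is meant among the compounds shown, and "the series" means these compounds.

Compound 2 `O=C(O)CNC(=O)c1c(O)c2c(n(Cc3ccc(OC(F)(F)F)cc3)c1=O)COC2` and compound 1 `O=C(O)CNC(=O)c1c(O)c2c(n(Cc3ccc(Cl)cc3)c1=O)COC2` share one core and differ only in the group on the aromatic ring of the benzyl arm. In an assay on Sf9 cells for inhibition of prolyl hydroxylase EGLN2 (Homo sapiens), read by TR-FRET, with stated times of 30 min and 2 h (a lower number here means a stronger inhibitor, a higher number a weaker inhibitor), compound 1 gives 2.1 nM and compound 2 gives 2.4 nM. The step of a 1.1-fold higher number from compound 1 to compound 2 (0.06 log units; within the scatter) is within the scatter, so the two values cannot be ordered. Among the measured compounds shown here, of the two numbers known, that of compound 2 is the higher, but only within the scatter of compound 1.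

Compound 3 `CC(C)(O)c1ccc(Cn2c3c(c(O)c(C(=O)NCC(=O)O)c2=O)COC3)cc1` is not yet measured. It differs from compound 2 in one place: 1-hydroxy-1-methylethyl in place of trifluoromethoxy on an aromatic carbon. For the measured compounds named here, the one measured step that bears on this position is a 1.1-fold higher number from compound 1 to compound 2 (0.06 log units; within the scatter), where one group replaced another at the same aromatic carbon without a change beyond the scatter. Going by the values given here, on that basis the step expected in this assay from compound 2 to compound 3 is small, a 1.3-fold higher number from compound 2 to compound 3 (0.10 log units; within the scatter), with no direction beyond the scatter; no measured pair shows how a group carrying a hydrogen-bond donor behaves here, so the range is kept wide. Compound 3 is therefore estimated at 3 nM, between 1.2 nM and 8 nM.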

Compound 3, half-maximal inhibitory concentration: 6.2 nM
The estimate for compound 3 lay 2.1-fold (0.32 log units) below the measured number; low and high end bracket the measured number.
By their numbers in this assay, from the lowest: compounds 1 and 2 (each within the scatter of the next); then compound 3.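

The new value shows that this aromatic carbon, para to a large group, does not accept every replacement equally in this assay. Chloro and trifluoromethoxy could not be told apart there, whereas 1-hydroxy-1-methylethyl gives a 2.6-fold higher number from compound 2 to compound 3 (0.41 log units; beyond the scatter) and a 3.0-fold higher number from compound 1 to compound 3 (0.47 log units; beyond the scatter), both modest but beyond the scatter, and it is the one group of the three that brings a hydrogen-bond donor to this position. No measurement of any other kind accompanies these numbers, so the compounds give no explanation for the step.

The compounds shown leave open whether the step follows the hydroxyl itself or the carbon framework that carries it, a question that a comparison with tert-butyl, the same framework without the hydroxyl, would address. Going by these compounds, it also remains open how an amine or a carboxylic acid on this aromatic carbon would read, and so whether the step belongs to hydrogen-bond donors in general or to this one group alone.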